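The source may report more compounds than this note shows. Statements on the series, on what has been measured and on what is new or still open speak of the compounds shown alone.

Compound 1, `CN(C)C(=O)c1cc2cnc(Nc3ccc(NC(=O)C4(C(=O)Nc5ccc(F)cc5)CC4)cc3F)nc2n1C1CCCC1`, gives 82.6% in a functional assay on NCI-H1299 cells (Homo sapiens) for inhibition, read by CCK-8 assay, with a stated time of 72 h, tested at 10 uM; a lower number here means less inhibition of growth, a higher number more inhibition of growth at the concentration tested.
Compound 2, `CN(C)C(=O)c1cc2cnc(Nc3ccc(NC(=O)C4(C(=O)Nc5ccc(Cl)c(C(F)(F)F)c5)CC4)cc3)nc2n1C1CCCC1`, gives 90.4% in this assay.
Compound 3, `CN(C)C(=O)c1cc2cnc(Nc3ccc(NC(=O)C4(C(=O)Nc5ccc(O)cc5)CC4)cc3)nc2n1C1CCCC1`, gives 89.7% in this assay.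

Compound 2 holds the highest of the three numbers, but its nearest neighbour, compound 3, sits within the scatter of it, and so does the furthest, compound 1; no ordering among the three can be claimed. Among the measured compounds shown here, the one single-point step available, a number 0.7 percentage points lower from compound 2 to compound 3 (within the scatter), swaps the aryl group on the amide-type nitrogen and leaves the growth inhibition unchanged within the scatter. Compound 1 differs from compound 2 in two places, so its value is only read alongside that of compound 2 and shows a similar level.

Compound 4, `CN(C)C(=O)c1cc2cnc(Nc3ccc(NC(=O)C4(C(=O)Nc5cccc(F)c5)CC4)cc3)nc2n1C1CCCC1`, differs from compound 2 by 3-fluorophenyl in place of 4-chloro-3-(trifluoromethyl)phenyl on an amide-type nitrogen. The change sits at the same amide-type nitrogen as the step from compound 2 to compound 3, and that step was within the scatter, so no movement beyond the scatter is expected in this assay for compound 4. The expected step of a number 2.4 percentage points lower from compound 2 to compound 4 (within the scatter) is therefore small. Compound 4 is estimated at 88% in this assay, with a range from 78% to 95%.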

Compound 4, percent growth inhibition at one concentration: 87%
The estimate for compound 4 lay 1 percentage points above the measured number; low and high end bracket the measured number.
By their numbers in this assay, from the lowest: compounds 1, 4, 3 and 2 (each within the scatter of the next).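

At the amide-type nitrogen whose other neighbour is a carbonyl carbon, this assay gives a number 3.4 percentage points lower from compound 2 to compound 4 (within the scatter) when 3-fluorophenyl replaces 4-chloro-3-(trifluoromethyl)phenyl and a number 2.7 percentage points lower from compound 3 to compound 4 (within the scatter) when it replaces 4-hydroxyphenyl. Among the compounds shown here, this position now has three aryl groups connected by single changes, and the smaller 3-fluorophenyl, with fewer heavy atoms than the group it replaces, leaves the growth inhibition unchanged within the scatter, so the earlier lack of movement is not confined to the one swap from compound 2 to compound 3. Nothing at hand explains why these changes leave the number in place.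

From the compounds shown here alone, all the groups compared at this nitrogen are still six-membered aromatic rings of carbon only, so it stays open whether a non-aromatic group, such as a cyclohexyl ring, a short alkyl chain ending in an amine, or a phenyl ring carrying a carboxylic acid, would move the number beyond the scatter. With only one concentration tested, these compounds also leave open whether the aryl groups would differ at lower concentrations.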